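The source may report more compounds than this note shows. Statements on the series, on what has been measured and on what is new or still open speak of the compounds shown alone.

In an ADME assay on HeLa cells (Homo sapiens) for cytotoxicity (on this read-out lower numbers stand for stronger inhibition and higher numbers for weaker inhibition), three compounds that share one core have been measured. Compound 1 `Cc1ncc([N+](=O)[O-])n1CCSC(=S)N1C(C)CCCC1C` gives 130 ug/mL and compound 3 `CCC1CCCCN1C(=S)SCCn1c([N+](=O)[O-])cnc1C` gives 94 ug/mL; these two values lie within the usual scatter of each other, so neither can be called the more or less toxic of the pair. Compound 2 `Cc1ncc([N+](=O)[O-])n1CCSC(=S)N1CCC(OS(C)(=O)=O)CC1` reaches only the limit of this assay, > 1000 ug/mL, which means no number is known for it, only that it is weak. This is the limit of > 1000 ug/mL in this assay, at which 1 of the 3 values shown sits.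

Compound 4 `Cc1ncc([N+](=O)[O-])n1CCSC(=S)N1CCC(OC(=O)CN2CCCCC2)CC1` has not yet been measured. It differs from compound 2 in one place: ((piperidin-1-yl)methyl)carbonyl in place of methylsulfonyl on an oxygen on a saturated carbon. Among the measured compounds shown here, no step between two measured compounds shows what such a change does in this assay, so the expectation rests on where compound 2 stands and on the values of compound 1 and compound 3, which are the only numbers available for this core. The step from compound 2 to compound 4 is expected to be an at least 2.0-fold lower number from compound 2 to compound 4 (0.30 log units; that floor lies within the scatter), a moderate move toward stronger inhibition, held with little confidence. Compound 4 is therefore estimated at 500 ug/mL, within a range from 150 ug/mL to 1000 ug/mL.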

Compound 4, half-maximal inhibitory concentration: 760 ug/mL
Compound 4: middle estimate off by 1.5-fold (0.18 log units), on the low side; measured number inside the range.
By their numbers in this assay, from the lowest: compounds 3 and 1 (each within the scatter of the next); then compound 4. At a limit, above all of these: compound 2.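

In this assay, the position held by methylsulfonyl on an oxygen on a saturated carbon now has a second group, and with ((piperidin-1-yl)methyl)carbonyl there, compound 4 gives a true number, 760 ug/mL. Among the compounds shown here, the change from methylsulfonyl to this larger, ring-bearing group amounts to an at least 1.3-fold lower number from compound 2 to compound 4 (0.11 log units; that floor lies within the scatter), which is a floor and not a full measure of the step, so the data show only that the true step is no smaller than this and may be larger. The real size stays unknown, and the floor alone cannot settle how much this change matters, because compound 2 has no number of its own, only a limit: the limit of > 1000 ug/mL in this assay, at which 1 of the 4 values shown sits.

With only this one exchange at the position, the compounds shown cannot tell whether the carbonyl or the piperidine ring accounts for the number of compound 4. As far as these compounds go, a plain acetyl group or a free hydroxyl on the same oxygen, or a morpholine ring in place of the piperidine ring, would help separate these two parts, and how any of them would read in this assay remains open.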